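A few compounds are considered here, and "the series" means these few. Any claim that something is new, unique, unknown or untested is made for them only; others in the source may bear on it.

Measured compounds in a functional assay on MDA-MB-468 cells (Homo sapiens) for antiproliferative activity, read by MTT assay, with a stated time of 72 h; on this read-out lower numbers stand for stronger inhibition and higher numbers for weaker inhibition:
- compound 1 `O=C(Nc1ccc(Cl)c(-c2nnc3c(Cl)cccn23)c1)c1ccc(C(F)(F)F)cc1Cl`: > 100000 nM, a limit of the assay
- compound 2 `O=C(Nc1ccc(Cl)c(-c2nnc3c(Cl)cccn23)c1)c1ccc(F)cc1Cl`: > 100000 nM, a limit of the assay
- compound 3 `Cc1nc(C(=O)Nc2ccc(Cl)c(-c3nnc4c(Cl)cccn34)c2)cs1`: > 100000 nM, a limit of the assay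

Compound 3 stands at the limit of > 100000 nM in this assay, at which 3 of the 3 values shown sit. Its number is a limit, as are the other two, so it cannot be ranked against them. The step that the two limits leave unreadable from compound 1 to compound 2 and the step that the two limits leave unreadable from compound 2 to compound 3 are both unreadable; each of their ends is a limit. Compound 4 `O=C(Nc1ccc(Cl)c(-c2nnc3c(Cl)cccn23)c1)c1ccc(Cl)cc1` arises from compound 3 by 4-chlorophenyl in place of 2-methyl-1,3-thiazol-4-yl on a carbonyl carbon. Among the compounds with values here, no measured step reads on this change: every variation of the group on the carbonyl carbon so far has ended at the limit of > 100000 nM in this assay, at which 3 of the 3 values shown sit, and the step from compound 2 to compound 3, which also changed that group, gave no readable movement. For compound 4 in this assay the expected outcome is therefore no readable step, a step that the limit leaves unreadable from compound 3 to compound 4, most likely again reported only as a limit. Compound 4 is estimated at 150000 nM, with a range from 40000 nM to 600000 nM.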

Compound 4, half-maximal inhibitory concentration: > 100000 nM
Compound 4 gave a limit, no number (the forecaster's own chance of this, stated with the estimate: 80%); the middle value does not contradict the limit.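

No new step can be read from compound 4 against compound 2 or compound 3, as each stands only as a limit: the limit of > 100000 nM in this assay, at which 4 of the 4 values shown sit.

The compounds shown leave open whether any group on the carbonyl carbon gives a measurable value in this assay.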